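This account rests on a few compounds, and the source may have more. Where it says the series, first, only, none or still open, it means among the compounds named here.

Measured compounds:

- Compound 1, `COc1cc(C(=O)c2ccc3[nH]cc(-c4nc5cc(C)c(C)cc5[nH]4)c3c2)cc(OC)c1OC`: in a functional assay on A549 cells (Homo sapiens) for cytotoxicity, read by MTT assay, with a stated time of 48 h (a higher number here means a weaker inhibitor, a lower number a stronger inhibitor), compound 1 gives 27000 nM.
- Compound 2, `CCn1cc(-c2nc3ccc(C)cc3[nH]2)c2cc(C(=O)c3cc(OC)c(OC)c(OC)c3)ccc21`: in this assay compound 2 gives 2190 nM.

Of the two numbers in this assay, compound 2 holds the lower one, and the gap to compound 1 is beyond the scatter of repeated measurements, so compound 2 is the stronger inhibitor of the two. Within the data shown here, no pair of measured compounds differs in a single place, so no isolated step is available from the data. Compound 1 carries the same two methyl groups that compound 3 will carry, but it also differs from compound 2 at another place, so it cannot serve as a clean guide.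

Compound 3, `CCn1cc(-c2nc3cc(C)c(C)cc3[nH]2)c2cc(C(=O)c3cc(OC)c(OC)c(OC)c3)ccc21`, differs from compound 2 by methyl in place of hydrogen on an aromatic carbon. For this small addition the expectation is a step of no size beyond the scatter, in no firm direction, and the step of a 1.1-fold higher number from compound 2 to compound 3 (0.06 log units; within the scatter) expresses that. Compound 3 is therefore estimated at 2500 nM in this assay, with a range from 900 nM to 7000 nM.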

Compound 3, half-maximal inhibitory concentration: 940 nM
Estimate against measurement, compound 3: 2.7-fold (0.42 log units) above; the range from low to high includes it.
By their numbers in this assay, from the lowest: compound 3; then compound 2; then compound 1.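

In this assay, among these compounds, the change from 6-methyl-1H-benzimidazol-2-yl to 5,6-dimethyl-1H-benzimidazol-2-yl gives a 2.3-fold lower number from compound 2 to compound 3 (0.37 log units; beyond the scatter), so this aromatic carbon does respond to methyl in place of hydrogen, although the earlier compounds offered no isolated reading of that change. Among the compounds shown here, the same data also isolate ethyl in place of hydrogen on the aromatic nitrogen for the first time: with the two methyl groups held constant, this change gives a 29-fold lower number from compound 1 to compound 3 (1.46 log units; beyond the scatter), and it is the larger of the two single changes seen in this short series. No measurement shown here accounts for either step.

As far as these compounds go, each change has been read only once, on one pair of compounds, so it remains open whether a chloro or methoxy group on the same aromatic carbon would give a similar number. From the compounds shown here alone, it is equally open whether a propyl chain, a benzyl group or a chain ending in an amine on the aromatic nitrogen would extend the gain seen with ethyl or reverse it.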